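The source may hold more compounds than are shown below. What is called first, only, known or untested is meant among the compounds shown, and "the series" means these compounds.

Compound 3 `CCCOc1ccc(C(=O)Nc2cc(C(=O)O)cc(C(=O)O)c2)cc1` is tested in a functional assay on the whole organism (stomach) with Rattus norvegicus as the target (a lower number here means that less compound is needed, a higher number that more compound is needed for the effect), where compound 3 gives 78 mg/kg, the highest of the three numbers shown. Going by the values given here, compound 1 `O=C(O)c1cc(NC(=O)c2ccc([N+](=O)[O-])cc2)cc(C(=O)O)c1` gives 61.1 mg/kg, and the only single-place step among the measured compounds is a 1.3-fold higher number from compound 1 to compound 3 (0.11 log units; within the scatter). Among the compounds with values here, compound 2 `N#Cc1ccc(C(=O)Nc2cccc(-c3nn[nH]n3)c2)cc1` gives 21.4 mg/kg, the lowest value here, but its structure differs from compound 3 in more than one place, so it gives no clean step. Compound 4 `O=C(O)c1cc(NC(=O)c2ccc(-c3nn[nH]n3)cc2)cc(C(=O)O)c1` differs from compound 3 by 2H-tetrazol-5-yl in place of propoxy on an aromatic carbon. Within the data shown here, no measured step isolates this change; the step to compound 3 shows that swapping the group on this carbon changed little, while compound 2 hints that a tetrazolyl can accompany a lower number. Compound 4 is therefore expected to show a 1.7-fold lower number from compound 3 to compound 4 (0.24 log units; within the scatter), with an estimated 45 mg/kg ranging from 20 mg/kg to 110 mg/kg.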

Compound 4, dose for 50% inhibition: 8.2 mg/kg
Estimate against measurement, compound 4: 5.5-fold (0.74 log units) above, outside the stated range (below it).
By their numbers in this assay, from the lowest: compound 4; then compound 2; then compounds 1 and 3 (each within the scatter of the next).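

In this assay the group on this aromatic carbon of the shared core clearly matters, since 2H-tetrazol-5-yl lowers the number against both propoxy (a 9.5-fold lower number from compound 3 to compound 4 (0.98 log units; beyond the scatter)) and nitro (a 7.5-fold lower number from compound 1 to compound 4 (0.87 log units; beyond the scatter)). Exchanging nitro for propoxy had stayed within the scatter, so a clear shift at this carbon appears only with 2H-tetrazol-5-yl. Nothing measured here accounts for this difference. Still open, going by these compounds, is whether an amine or a sulfonamide on this same carbon would give a similarly low number, and whether the low number needs both carboxylic acids on the core.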